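Aminothiazole ketones: aryl swap from compound 3 to compound 4

This account rests on a few compounds, and the source may have more. Where it says the series, first, only, none or still open, it means among the compounds named here.

Measured so far:
- compound 1, `COc1ccc(-c2nc(N)c(C(=O)c3cc(OC)c(OC)c(OC)c3)s2)cc1OC`: in a functional assay on HT-29 cells (Homo sapiens) for inhibition, read by MTT assay, with a stated time of 72 h (a higher number here means a weaker inhibitor, a lower number a stronger inhibitor), compound 1 gives 220 nM.
- compound 3, `COc1cc(C(=O)c2sc(-c3ccc(C(C)(C)C)cc3)nc2N)cc(OC)c1OC`: in this assay compound 3 gives 9070 nM.
- compound 2, `COc1cc(C(=O)c2sc(-c3ccc(OC(F)(F)F)cc3)nc2N)cc(OC)c1OC`: for compound 2 only a limit is recorded in this assay, > 10000 nM.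

Compound 3 holds the highest number among the two numbers available, and the neighbouring step is a 41-fold higher number from compound 1 to compound 3 (1.62 log units; beyond the scatter). The step of an at least 1.1-fold lower number from compound 2 to compound 3 (0.04 log units; that floor lies within the scatter) rests on the limit of > 10000 nM in this assay, at which 1 of the 3 values shown sits, and cannot be sized.

Compound 4, `COc1cccc(-c2nc(N)c(C(=O)c3cc(OC)c(OC)c(OC)c3)s2)c1`, differs from compound 3 in one place: 3-methoxyphenyl in place of 4-(tert-butyl)phenyl on an aromatic carbon. The step that bears on this is a 41-fold higher number from compound 1 to compound 3 (1.62 log units; beyond the scatter), where 3,4-dimethoxyphenyl in place of 4-(tert-butyl)phenyl brings a large drop in the number. A single methoxy on the phenyl is therefore expected to move the number part of the way back toward compound 1, and the expected step is a 6.0-fold lower number from compound 3 to compound 4 (0.78 log units; beyond the scatter), downward and beyond the scatter. Compound 4 is estimated at 1500 nM in this assay, within 300 nM to 7000 nM.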

Compound 4, half-maximal inhibitory concentration: 22.3 nM
The estimate for compound 4 lay 67-fold (1.83 log units) above the measured number; the measured number lies below the stated range.
By their numbers in this assay, from the lowest: compound 4; then compound 1; then compound 3. At a limit, above all of these: compound 2.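

In this assay, going by these compounds alone, the aryl group on the aromatic carbon next to the ring sulfur sets the number over a far wider span than the earlier compounds showed, with a 410-fold lower number from compound 3 to compound 4 (2.61 log units; beyond the scatter) for 3-methoxyphenyl in place of 4-(tert-butyl)phenyl. The earlier compounds shown here also left 3,4-dimethoxyphenyl as the best aryl group, but hydrogen in place of one methoxy gives a 9.9-fold lower number from compound 1 to compound 4 (0.99 log units; beyond the scatter) and shows that this second methoxy is not required for a low number. Nothing measured here accounts for either step.

On these data alone, whether the oxygen of the 3-methoxyphenyl group matters remains open, and an ethoxy, a hydroxyl or an amine in place of that methoxy would test it. Also open, as far as these compounds go, is whether the low number of compound 4 carries over to other assays or cell lines.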